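The compounds below may be only part of what the source reports. "The series", "measured", "known", "first", "only" and "open" are said of these compounds alone.

Measured compounds:
- compound 1, `CC1CCN(C2CCN(S(=O)(=O)c3ccc(C(C)(C)C)cc3)CC2)CC1`: > 5000 nM in a functional assay on DLD-1 cells (Homo sapiens) for antiproliferative activity, read by CellTiter-Glo, with a stated time of 72 h; on this read-out higher numbers stand for weaker inhibition and lower numbers for stronger inhibition
- compound 2, `COc1ccccc1-c1ccc(S(=O)(=O)N2CCC(N3CCC(C)CC3)CC2)cc1`: 26 nM
- compound 3, `CC1CCN(C2CCN(S(=O)(=O)c3cnc(Cl)s3)CC2)CC1`: 1800 nM

The value of compound 1 in this assay is a limit of the assay, not a number. Among the two numbers shown, compound 3 stands highest, with compound 2 nearest to it and well beyond the scatter. Among the measured compounds shown here, the one step measured in one place, an at least 190-fold lower number from compound 1 to compound 2 (2.28 log units; beyond the scatter), lies on an aromatic carbon and does not touch the sulfonyl sulfur.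

Compound 4, `CC1CCN(C2CCN(S(=O)(=O)c3ccc(C#N)cc3)CC2)CC1`, has not yet been measured. It differs from compound 3 in one place: 4-cyanophenyl in place of 2-chloro-1,3-thiazol-5-yl on a sulfonyl sulfur. No measured step changes the group on the sulfonyl sulfur, so the size of this step cannot be read from any shown pair. The only related pattern is that compound 1, which also carries a phenyl bearing a single para substituent on the sulfonyl sulfur, sits at the limit (the limit of > 5000 nM in this assay, at which 1 of the 3 values shown sits), while the far stronger compound 2 carries a larger aryl group there.

Compound 4 is therefore expected to give 3000 nM in this assay, within 800 nM to 10000 nM. The estimate means a step of a 1.7-fold higher number from compound 3 to compound 4 (0.22 log units; within the scatter), which is expected to remain weak and may well be reported only as a limit.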

Compound 4, half-maximal inhibitory concentration: 2800 nM
Estimate against measurement, compound 4: 1.1-fold (0.03 log units) above; low and high end bracket the measured number.
By their numbers in this assay, from the lowest: compound 2; then compounds 3 and 4 (each within the scatter of the next). At a limit, above all of these: compound 1.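

In this assay, the exchange on the sulfonyl sulfur, a 1.6-fold higher number from compound 3 to compound 4 (0.19 log units; within the scatter), shows that a five-membered aromatic ring with 2 hetero atoms and a six-membered aromatic ring of carbon only cannot be told apart at this position, as 2-chloro-1,3-thiazol-5-yl and 4-cyanophenyl carry them here. On the aromatic carbon, cyano in place of 2-methoxyphenyl gives a 110-fold higher number from compound 2 to compound 4 (2.03 log units; beyond the scatter), and cyano in place of tert-butyl gives an at least 1.7-fold lower number from compound 1 to compound 4 (0.25 log units; that floor lies within the scatter), so only the exchange against 2-methoxyphenyl is a difference beyond the scatter. The value of compound 1 is a limit of the assay and not a number: the limit of > 5000 nM in this assay, at which 1 of the 4 values shown sits.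

The compounds shown leave open whether an amine or a carboxylic acid on that aromatic carbon would behave like cyano or like 2-methoxyphenyl, and whether the low number of compound 2 depends on the methoxy group or would also be reached with an unsubstituted phenyl there. The rest of the core is the same in all four compounds, so nothing here shows what a change in that part would do.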